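Tetrazole to acylsulfonamide on the aryl-pyridine series

The source may report more compounds than this note shows. Statements on the series, on what has been measured and on what is new or still open speak of the compounds shown alone.

Working notes on two measured compounds and one pending. In an assay on cells for binding affinity to Myc proto-oncogene protein (Homo sapiens) (on this read-out higher numbers stand for weaker inhibition and lower numbers for stronger inhibition), compound 1 `Cn1ccnc1-c1cc(-c2ccc(C(N)=O)cc2)cc(-c2ccc(C#N)cc2)n1` gives 40000 nM, a value that ends up as the higher of the two. Compound 2 `N#Cc1ccc(-c2cc(-c3ccc(-c4nnn[nH]4)cc3)cc(-c3ccco3)n2)cc1` gives 2000 nM in this assay, the lower of the two numbers and separated from compound 1 by a gap well beyond the usual scatter. For the measured compounds named here, no step between compounds differing in a single place is available here, so the two values show only that the pair as a whole differs.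

Compound 3 `CS(=O)(=O)NC(=O)c1ccc(-c2cc(-c3ccc(C#N)cc3)nc(-c3ccco3)c2)cc1` carries the change (methylsulfonyl)carbamoyl in place of 1H-tetrazol-5-yl on an aromatic carbon relative to compound 2. Both the leaving and the entering group hold one donor and three acceptors, so no large step is expected, with a slight drift toward a higher number considered possible. The step from compound 2 is estimated as a 1.5-fold higher number from compound 2 to compound 3 (0.18 log units; within the scatter). For compound 3 the expected value in this assay is 3000 nM, within a range of 800 nM to 12000 nM.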

Compound 3, half-maximal inhibitory concentration: 10000 nM
Beside the measured number, compound 3's estimate is 3.3-fold (0.52 log units) below it; measured number inside the range.
By their numbers in this assay, from the lowest: compound 2; then compound 3; then compound 1.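

In this assay, placing (methylsulfonyl)carbamoyl in place of 1H-tetrazol-5-yl gives a 5.0-fold higher number from compound 2 to compound 3 (0.70 log units; beyond the scatter), the first single-place step available in this series. It shows that this aromatic carbon, para to a large group, is sensitive to the identity of its substituent, even though the leaving and entering groups have the same counts of hydrogen-bond donors and acceptors, so those counts alone do not predict the result here.

The compounds shown leave open whether a carboxylic acid at the same carbon would sit nearer compound 2 or compound 3, and whether a phenylsulfonyl group in place of the methylsulfonyl part would move the number in either direction. A single step also cannot show whether the same change would give a similar shift on a different core. No measurement available here accounts for the size of this step.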